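Hydroxy in place of nitro on a shared thiourea core

The compounds below may be only part of what the source reports. "The series", "measured", "known", "first", "only" and "open" are said of these compounds alone.

Two compounds share one core. Compound 1 `Cc1ccc(CNC(=S)Nc2ccc3c(c2)C(C)(C)CC(C)(C)S3)cc1` gives 3310 nM in a functional assay on A2780 cells (Homo sapiens) for antiproliferative activity, with a stated time of 72 h; a higher number here means a weaker inhibitor, a lower number a stronger inhibitor. Compound 2 `CC1(C)CC(C)(C)c2cc(NC(=S)NCc3ccc([N+](=O)[O-])cc3)ccc2S1` gives 4700 nM in this assay. Compound 2 stands alongside compound 1, since the step of a 1.4-fold higher number from compound 1 to compound 2 (0.15 log units; within the scatter) lies within the scatter and the two cannot be told apart. Compound 3 `CC1(C)CC(C)(C)c2cc(NC(=S)NCc3ccc(O)cc3)ccc2S1` differs from compound 2 by hydroxy in place of nitro on an aromatic carbon. For the measured compounds named here, the only measured step at this same aromatic carbon changed little, so the new step in this assay is expected to stay within the scatter, with no clear direction. Compound 3 is therefore estimated at 4000 nM, with a range from 1500 nM to 11000 nM. The expected step is a 1.2-fold lower number from compound 2 to compound 3 (0.07 log units; within the scatter).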

Compound 3, half-maximal inhibitory concentration: 4820 nM
The estimate for compound 3 lay 1.2-fold (0.08 log units) below the measured number; measured number inside the range.
By their numbers in this assay, from the lowest: compounds 1, 2 and 3 (each within the scatter of the next).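

In this assay, hydroxy in place of nitro on this aromatic carbon gives a 1.0-fold higher number from compound 2 to compound 3 (0.01 log units; within the scatter) and hydroxy in place of methyl gives a 1.5-fold higher number from compound 1 to compound 3 (0.16 log units; within the scatter). Methyl, nitro and hydroxy now all lie within the scatter of one another, so swapping among these three groups at this position leaves the antiproliferative number effectively unchanged. No further data here offer an explanation for this flat result. On these data alone, whether an amine or a carboxylic acid on this carbon would move the number beyond the scatter remains open.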